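This account rests on a few compounds, and the source may have more. Where it says the series, first, only, none or still open, it means among the compounds named here.

Measured in a functional assay on PC-3 cells (Homo sapiens) for cytotoxicity, read by MTT assay, with a stated time of 48 h; on this read-out higher numbers stand for weaker inhibition and lower numbers for stronger inhibition:
- Compound 1 `COc1ccc(-c2c(-c3cc(OC)c(OC)c(OC)c3)noc2N)cc1OC`: 21100 nM
- Compound 2 `COc1ccc(-c2c(-c3cc(OC)c(OC)c(OC)c3)noc2NC(C)=O)cc1OC`: > 50000 nM (a limit of the assay, not a number)
- Compound 3 `COc1ccc(-c2c(-c3cc(OC)c(OC)c(OC)c3)noc2N(C(C)=O)C(C)=O)cc1`: 360 nM

Compound 3 gives the lowest number here at 360 nM, well under compound 1 at 21100 nM. Compound 4 `COc1ccc(-c2c(-c3cc(OC)c(OC)c(OC)c3)noc2N(C(C)=O)C(C)=O)cc1OC` differs from compound 3 in one place: methoxy in place of hydrogen on an aromatic carbon. A methoxy takes the place of a hydrogen on an aromatic carbon, turning 4-methoxyphenyl into 3,4-dimethoxyphenyl.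

Among the compounds with values here, no measured step makes this exact change. Within the data shown here, the only step available, an at least 2.3-fold higher number from compound 1 to compound 2 (0.37 log units; beyond the scatter), swaps acetyl for hydrogen on a nitrogen, so it bears on this question only loosely. Still, compound 1 and compound 2 both carry 3,4-dimethoxyphenyl and both sit high, though their nitrogens differ from that of compound 4. This points, weakly, toward a weaker result. The expected change is a 3.3-fold higher number from compound 3 to compound 4 (0.52 log units; beyond the scatter), toward a higher number. For compound 4 the estimated value is 1200 nM, with an expected range of 150 nM to 10000 nM.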

Compound 4, half-maximal inhibitory concentration: > 50000 nM
Compound 4: no number, only a limit; the forecaster's own chance of this, stated with the estimate: 8%; middle value at least 41-fold (1.61 log units) away from the limit.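

In this assay, one added methoxy, turning 4-methoxyphenyl into 3,4-dimethoxyphenyl, gives an at least 130-fold higher number from compound 3 to compound 4 (2.14 log units; beyond the scatter), so the low number of compound 3 depends on this ring position staying free of a methoxy. Compound 4 gives > 50000 nM, which is a limit of the assay and not a number. The diacetylamino group alone therefore does not bring a low number: with 3,4-dimethoxyphenyl in place, swapping amino for it gives an at least 2.3-fold higher number from compound 1 to compound 4 (0.37 log units; beyond the scatter).

On these data alone, the step between compound 2 and compound 4 cannot be read, and the full size of both rises stays hidden because of the ceiling on this read-out: the limit of > 50000 nM in this assay, at which 2 of the 4 values shown sit. Whether a fluorine atom or a hydroxyl group in that same place, ortho to a methoxy group, would keep the number low also remains open.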